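Series notes: the aryl change from compound 3 to compound 4

The compounds below may be only part of what the source reports. "The series", "measured", "known", "first", "only" and "open" are said of these compounds alone.

Measured so far:
- compound 1 `O=S(=O)(NCCCNCc1ccc(Cl)c(Cl)c1)c1cc(C(F)(F)F)cc(C(F)(F)F)c1`, in a functional assay on MIA PaCa-2 cells (Homo sapiens) for inhibition, read by MTT assay, with a stated time of 72 h (a higher number here means a weaker inhibitor of growth, a lower number a stronger inhibitor of growth), compound 1 gives 2700 nM
- compound 2 `O=S(=O)(NCCCNCc1ccc(Cl)c(C(F)(F)F)c1)c1cc(C(F)(F)F)cc(C(F)(F)F)c1`, compound 2 gives 7400 nM
- compound 3 `O=S(=O)(NCCCNCc1cccc2ccccc12)c1cc(C(F)(F)F)cc(C(F)(F)F)c1`, compound 3 gives 2800 nM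

Compound 3 stands second highest of the three numbers. Its nearest neighbour is compound 1: a 1.0-fold higher number from compound 1 to compound 3 (0.02 log units; within the scatter). Compound 2 is furthest away: a 2.6-fold lower number from compound 2 to compound 3 (0.42 log units; beyond the scatter).

Compound 4 `COc1cccc(CNCCCNS(=O)(=O)c2cc(C(F)(F)F)cc(C(F)(F)F)c2)c1` is not yet measured. The change from compound 3 is 3-methoxyphenyl in place of naphthalen-1-yl on a saturated chain carbon bound to an amine nitrogen. Both steps that already vary this same position bear on it. One of them, a 1.0-fold higher number from compound 1 to compound 3 (0.02 log units; within the scatter), was within the scatter; the other, a 2.6-fold lower number from compound 2 to compound 3 (0.42 log units; beyond the scatter), was modest. Going by the values given here, the only other step in the set, a 2.7-fold higher number from compound 1 to compound 2 (0.44 log units; beyond the scatter), changes a substituent on the ring at this position and was also modest. So the aryl group on the chain carbon bound to the amine nitrogen has moved this assay by at most a modest amount in either direction among these three compounds.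

On that basis compound 4 is expected to sit close to compound 3, with a step of a 1.4-fold higher number from compound 3 to compound 4 (0.15 log units; within the scatter), leaning slightly toward a higher number. The estimate for compound 4 is 4000 nM, with a range from 1500 nM to 12000 nM.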

Compound 4, concentration for 50% growth inhibition: 3400 nM
The estimate for compound 4 lay 1.2-fold (0.07 log units) above the measured number, within the range that was stated.
By their numbers in this assay, from the lowest: compounds 1, 3 and 4 (each within the scatter of the next); then compound 2.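

In this assay, one six-membered aromatic ring with a methoxy group replaces the two rings of naphthalen-1-yl with a 1.2-fold higher number from compound 3 to compound 4 (0.08 log units; within the scatter), so this change, which also adds a hydrogen-bond acceptor, leaves the number within the scatter. The same holds against the 3,4-dichlorophenyl group, with a 1.3-fold higher number from compound 1 to compound 4 (0.10 log units; within the scatter), so compounds 1, 3 and 4 read alike despite carrying three different aryl groups, while compound 2 goes against that grouping, as a 2.2-fold lower number from compound 2 to compound 4 (0.34 log units; beyond the scatter) shows a modest step beyond the scatter. No supporting measurement accompanies these numbers to explain why these aryl groups read alike or why the 4-chloro-3-(trifluoromethyl)phenyl group stands apart.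

Open, going by these compounds, is whether a pyridine ring, a cyclohexyl ring or an unsubstituted phenyl ring at this place would stay with compounds 1, 3 and 4 or move away as compound 2 does. Also open, on these data alone, is whether the same flat reading would hold with a longer chain in the shared core, or with an amide in place of the amine.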